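This account rests on a few compounds, and the source may have more. Where it says the series, first, only, none or still open, it means among the compounds named here.

Measured compounds:
Compound 1, `CC(C)(C)C1=C(C(=O)O)N2C(=O)[C@H]([C@@H](O)c3ccccc3)[C@H]2O1`: 8.9 h
Compound 2, `CC(C)(C)C1=C(C(=O)O)N2C(=O)[C@H]([C@@H](O)c3ccc(O)cc3)[C@H]2O1`: 10.3 h

Of the compounds shown here, two sharing one core have been tested in an ADME assay, in phosphate buffer, at 28 degrees C, at pH 7.0; a lower number here means that the compound disappears faster, a higher number that the compound lasts longer. In this assay compound 1 gives 8.9 h and compound 2 gives 10.3 h. Among the measured compounds shown here, the only measured step, a 1.2-fold higher number from compound 1 to compound 2 (0.06 log units; within the scatter), lies within the scatter, so the two compounds cannot be told apart on these numbers; compound 2 simply carries the nominally higher of the two readings, with compound 1 as its only neighbour.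

Compound 3, `CC(C)(C)C1=C(C(=O)O)N2C(=O)[C@H]([C@@H](O)c3ccncc3)[C@H]2O1`, differs from compound 2 by pyridin-4-yl in place of 4-hydroxyphenyl on a saturated chain carbon bound to an oxygen on a saturated carbon and a saturated ring carbon. For the measured compounds named here, no measured step covers this exchange of one aromatic ring for another. Going by the values given here, the one step that exists, from compound 1 to compound 2, altered the same aromatic ring and produced no change beyond the scatter. On that basis alone, the step from compound 2 to compound 3 is expected to be small as well, with no clear direction, estimated as a 1.1-fold lower number from compound 2 to compound 3 (0.04 log units; within the scatter). For compound 3 the half-life in this assay is therefore expected to be about 9.5 h, with a range from 5 h to 18 h.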

Compound 3, half-life: 6 h
The estimate for compound 3 lay 1.6-fold (0.20 log units) above the measured number; low and high end bracket the measured number.
By their numbers in this assay, from the lowest: compounds 3, 1 and 2 (each within the scatter of the next).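

The position on a saturated chain carbon bound to an oxygen on a saturated carbon and a saturated ring carbon now has its first exchange of the whole aromatic ring, with pyridin-4-yl, a ring with a hetero atom, entering for rings of carbon only, and in this assay this gives a 1.7-fold lower number from compound 2 to compound 3 (0.23 log units; within the scatter) and a 1.5-fold lower number from compound 1 to compound 3 (0.17 log units; within the scatter). Both steps stay within the scatter, so compound 3 cannot be told apart from compound 1 or compound 2, and so far neither a change on the aromatic ring nor the exchange of that ring has given a step beyond the scatter at this position. Nothing available offers an explanation for these readings.

Going by these compounds, it remains open whether a group without an aromatic ring at this place, such as cyclohexyl or a short alkyl chain, would give a step beyond the scatter. Also open, on these data alone, is whether an amine or a carboxylic acid on the phenyl ring, or pyridin-3-yl in place of pyridin-4-yl, would do so.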